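The compounds below may be only part of what the source reports. "The series", "measured", "known", "first", "only" and "open" are said of these compounds alone.

Compound 3 `COc1ccc(/C=C/C(=O)c2ccccc2NC(=O)NS(=O)(=O)c2ccc(C)cc2)c(OC)c1` stands second highest of the three numbers in an ADME assay on the whole organism for cytotoxicity, with Artemia salina as the target, with a stated time of 24 h (a lower number here means that less compound is needed, a higher number that more compound is needed for the effect), where compound 3 gives 16 ug/mL. Compound 2 `COc1ccc(/C=C/C(=O)c2ccccc2NC(=O)NS(=O)(=O)c2ccc(C)cc2)cc1OC` gives 12.9 ug/mL, and compound 1 `Cc1ccc(S(=O)(=O)NC(=O)Nc2ccccc2C(=O)/C=C/c2ccc(N(C)C)cc2)cc1` gives 38.1 ug/mL. The steps of a 3.0-fold lower number from compound 1 to compound 2 (0.47 log units; beyond the scatter) and a 2.4-fold lower number from compound 1 to compound 3 (0.38 log units; beyond the scatter) were both modest and beyond the scatter, while a 1.2-fold higher number from compound 2 to compound 3 (0.09 log units; within the scatter) stayed within it. Compound 4 `Cc1ccc(S(=O)(=O)NC(=O)Nc2ccccc2C(=O)/C=C/c2cccc(O)c2)cc1` differs from compound 3 by 3-hydroxyphenyl in place of 2,4-dimethoxyphenyl on a double-bonded chain carbon bound to a double-bonded chain carbon. Going by the values given here, no measured step trades a methoxy-bearing ring for a 3-hydroxyphenyl, so the earlier aryl swaps show only that changes at this place moved this assay modestly. A step of a 1.3-fold higher number from compound 3 to compound 4 (0.10 log units; within the scatter) is therefore expected. Compound 4 is estimated at 20 ug/mL, within 8 ug/mL to 50 ug/mL.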

Compound 4, concentration for half-maximal effect: 39.3 ug/mL
Compound 4: the middle estimate sits 2.0-fold (0.29 log units) below what was measured, and the stated range covers the measured number.
By their numbers in this assay, from the lowest: compounds 2 and 3 (each within the scatter of the next); then compounds 1 and 4 (each within the scatter of the next).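

In this assay the 3-hydroxyphenyl ring parts from both dimethoxyphenyl rings (a 2.5-fold higher number from compound 3 to compound 4 (0.39 log units; beyond the scatter) and a 3.0-fold higher number from compound 2 to compound 4 (0.48 log units; beyond the scatter)) yet stands level with 4-(dimethylamino)phenyl (a 1.0-fold higher number from compound 1 to compound 4 (0.01 log units; within the scatter)). Among these four compounds, then, only the two dimethoxyphenyl rings give the lower numbers, so this place separates the aryl groups into two tiers rather than showing a single small effect. Nothing available gives a reason for this split. On these data alone, whether the hydroxyl itself or its ring position sets the number stays open, as does what an unsubstituted phenyl or a 4-hydroxyphenyl ring would give in this assay.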